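The compounds below may be only part of what the source reports. "The series", "measured", "known", "first", "only" and "open" are said of these compounds alone.

Measured so far: compound 1 `O=C(NCc1ccc(S(=O)(=O)c2cccc(F)c2)cc1)c1cc2cnccc2[nH]1`, 79%; compound 2 `O=C(NCc1ccc(S(=O)(=O)c2ccccc2)cc1)c1cc(-c2cccnc2)[nH]n1`, 67%.

In an ADME assay on microsomes from liver (Homo sapiens) for metabolic stability, read by LC-MS, with a stated time of 30 min, tested at 1 uM (on this read-out lower numbers stand for a less stable compound and higher numbers for a more stable compound), compound 1 gives 79%, the higher of the two numbers, while compound 2 gives 67%, a gap beyond the scatter. Compound 3 `O=C(NCc1ccc(S(=O)(=O)c2ccccc2)cc1)c1cc2cnccc2[nH]1` differs from compound 1 by hydrogen in place of fluoro on an aromatic carbon. Among the compounds with values here, no measured pair shows this change, so the size of the step is open. Compound 3 is expected to stay close to compound 1, with a small decrease at most and possibly none beyond the scatter, a step of a number 7 percentage points lower from compound 1 to compound 3 (within the scatter). In this assay compound 3 is estimated at 72%, within a range from 58% to 85%.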

Compound 3, percent of the compound remaining: 75%
For compound 3 the middle estimate is 3 percentage points below the measured one, and the stated range covers the measured number.
By their numbers in this assay, from the lowest: compounds 2, 3 and 1 (each within the scatter of the next, the first and the last beyond it).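

In this assay, within the data shown here, the change from 3-fluorophenyl to phenyl gives a number 4 percentage points lower from compound 1 to compound 3 (within the scatter) and so offers the first comparison at a single place, showing that, on the core of compound 1, the read-out does not separate fluoro from hydrogen at this aromatic carbon. The fluoro is therefore not required for a number in this range. Nothing measured here speaks to why the two compounds read alike. From the compounds shown here alone, whether a chloro, methoxy or trifluoromethyl group at this place would also read alike stays open, as does whether the same change would behave similarly on the core of compound 2.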